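Removing a Trifluoromethyl Group: Cytotoxicity on Lung Cells

This account rests on a few compounds, and the source may have more. Where it says the series, first, only, none or still open, it means among the compounds named here.

Of the compounds shown here, three have been tested in an ADME assay on A549 cells (Homo sapiens) for cytotoxicity, read by MTT assay, tested at 100 uM; on this read-out lower numbers stand for a stronger effect and higher numbers for a weaker effect at the one concentration tested. Compound 1 `COc1ccc(C2CNC(=O)NC2)cc1O[C@@H]1C[C@H]2CC[C@H]1C2` gives 43.3%, compound 2 `C=CCSc1nsc(NC(=O)Nc2ccc(Cl)cc2C(F)(F)F)n1` gives 43.1%, and compound 3 `C#CCSc1nsc(NC(=O)Nc2ccc(Cl)c(C(F)(F)F)c2)n1` gives 18%. On these numbers compound 2 stands second highest; its nearest neighbour is compound 1, within the usual scatter, while compound 3 lies furthest away, beyond the scatter, with the stronger effect. Compound 4 `C=CCSc1nsc(NC(=O)Nc2ccc(Cl)cc2)n1` is still to be measured in this assay. It differs from compound 2 in one place: hydrogen in place of trifluoromethyl on an aromatic carbon. Going by the values given here, no pair of measured compounds differs in exactly this way, so the size of this step cannot be read from them. The step of a number 6.9 percentage points higher from compound 2 to compound 4 (within the scatter) is expected to stay within the scatter, in either direction. Compound 4 is estimated to give 50%, between 30% and 75%.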

Compound 4, a percentage reported as activity, at one concentration (the size of the read-out at that concentration, not a potency): 15.1%
Compound 4: middle estimate off by 34.9 percentage points, on the high side; measured number outside the range, below it.
By their numbers in this assay, from the lowest: compounds 4 and 3 (each within the scatter of the next); then compounds 2 and 1 (each within the scatter of the next).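

In this assay, hydrogen in place of trifluoromethyl on this aromatic carbon gives a number 28 percentage points lower from compound 2 to compound 4 (beyond the scatter), so the effect at the one concentration tested is stronger once the group has gone. This is the first change in a single place among the compounds shown, and it shows that what sits at this position matters for this read-out. No measurement shown here explains the step. Open, going by these compounds, is what a different group at this carbon, such as a methyl or an amine, would give, and whether the same step would appear on another core.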